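From a Protected Chain to a Free Piperidine

The compounds below may be only part of what the source reports. "The series", "measured", "known", "first", "only" and "open" are said of these compounds alone.

Compound 1 `O=C(Nc1cccc2cccnc12)c1ncccn1` carries the shared core with no side chain; in a functional assay on MIA PaCa-2 cells (Homo sapiens) for inhibition, read by MTT assay, with a stated time of 72 h (a lower number here means a stronger inhibitor, a higher number a weaker inhibitor), compound 1 gives 330 nM. Compound 2 `CC(C)(C)OC(=O)NCCOc1cc(NC(=O)c2ncccn2)c2ncccc2c1` adds a chain ending in (tert-butoxycarbonyl)amino through an oxygen on an aromatic ring. In this assay compound 2 gives > 10000 nM, which is a limit of the assay and not a number. Compound 2 thus sits at the limit of > 10000 nM in this assay, at which 1 of the 2 values shown sits, so compound 2 stands at the weak end of the two values shown. Compound 3 `O=C(Nc1cc(OCCC2CCNCC2)cc2cccnc12)c1ncccn1` keeps that chain but changes its end: piperidin-4-yl in place of (tert-butoxycarbonyl)amino on a saturated chain carbon, two bonds along the chain from an oxygen on an aromatic ring. For the measured compounds named here, no step between measured compounds is known, so the size of this change rests on compound 1 and compound 2 alone. Compound 1, with 330 nM and no chain at all, marks the level a chain-bearing analogue might approach. The step of an at least 5.0-fold lower number from compound 2 to compound 3 (0.69 log units; beyond the scatter) is expected to move toward stronger inhibition, beyond the scatter. Compound 3 is estimated at 2000 nM, within 300 nM to 10000 nM.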

Compound 3, half-maximal inhibitory concentration: > 10000 nM
Compound 3: only a limit was reported (the forecaster's own chance of this, stated with the estimate: 30%); middle value at least 5.0-fold (0.69 log units) from the limit.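

Replacing the (tert-butoxycarbonyl)amino end with piperidin-4-yl does not bring the chain off the limit in this assay, and compound 3, like compound 2, ends at a limit of the assay and not at a number: the limit of > 10000 nM in this assay, at which 2 of the 3 values shown sit.

The step between these two compounds cannot be read, so neither end of the chain can be ranked against the other. The change that can be read is 2-(piperidin-4-yl)ethoxy in place of hydrogen on an aromatic carbon, which gives an at least 30-fold higher number from compound 1 to compound 3 (1.48 log units; beyond the scatter), so a free piperidine at the end of this chain leaves the compound a much weaker inhibitor than the unsubstituted core.

As far as these compounds go, it remains open how far below the limit compound 2 and compound 3 might lie. Also open, from the compounds shown here alone, is whether a simple methoxy group, a primary amine or a carboxylic acid at this position would stay closer to compound 1, at 330 nM.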